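Shortening the Hydroxyethyl Chain: Cytotoxicity Expected for Compound 3

The source may hold more compounds than are shown below. What is called first, only, known or untested is meant among the compounds shown, and "the series" means these compounds.

Compound 1, `Fc1cccc(F)c1Cc1cnc(Nc2ccc(COc3ccncc3)cc2)o1`, in an ADME assay on MT2 cells (Homo sapiens) for cytotoxicity, read by MTT assay (on this read-out higher numbers stand for lower toxicity in this test and lower numbers for higher toxicity in this test), gives > 100000 nM, which is a limit of the assay. Compound 2, `OCCc1ccc(Nc2ncc(Cc3c(F)cccc3F)o2)cc1`, in this assay gives 35000 nM.

In this assay compound 2 stands as the only number shown; the other value is a limit. The step between these two is an at least 2.8-fold lower number from compound 1 to compound 2 (0.45 log units; beyond the scatter), carried by a hydroxymethyl in place of (pyridin-4-yl)oxy on a saturated chain carbon bound to an aromatic carbon, and it rests on (the limit of > 100000 nM in this assay, at which 1 of the 2 values shown sits), so only its lower bound is known.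

Compound 3, `OCc1ccc(Nc2ncc(Cc3c(F)cccc3F)o2)cc1`, has not yet been measured. It differs from compound 2 by hydroxy in place of hydroxymethyl on a saturated chain carbon bound to an aromatic carbon. Among the measured compounds shown here, the single measured step concerns a different group and does not directly bear on trimming hydroxymethyl to hydroxy on that chain carbon; no measured step tests this change. Compound 3 is therefore expected to stay close to compound 2, with a step of no change at the digits printed from compound 2 to compound 3 (within the scatter) in this assay that is not expected to go beyond the scatter. Compound 3 is estimated at 35000 nM, within a range of 15000 nM to 85000 nM.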

Compound 3, half-maximal cytotoxic concentration: > 100000 nM
Compound 3: a limit, no number; the forecaster's own chance of this, stated with the estimate: 20%; middle value at least 2.8-fold (0.45 log units) away from the limit.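

Shortening 2-hydroxyethyl to hydroxymethyl in this assay gives an at least 2.8-fold higher number from compound 2 to compound 3 (0.45 log units; beyond the scatter), so the read-out responds to this change on the saturated chain carbon bound to an aromatic carbon, even though the hydrogen-bond donor and acceptor counts of the leaving and entering groups are the same. Among the compounds shown here, on this read-out, compound 3 shows lower toxicity in this test than compound 2, and compound 2, with its 2-hydroxyethyl group, is now the only one of the three compounds to give a number rather than a limit. The true size of this step remains unknown beyond its lower bound, and the step between compound 1 and compound 3 cannot be read: the limit of > 100000 nM in this assay, at which 2 of the 3 values shown sit.

The compounds shown leave open whether the lower number of compound 2 follows from chain length alone or also needs the terminal hydroxy, which a longer chain such as 3-hydroxypropyl or an aminoethyl group could help to separate. They also leave open how far the number of compound 3 lies beyond the limit of the test.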